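Moving the carbonyl within the oxopiperazine of compound 3

The source may hold more compounds than are shown below. What is called first, only, known or untested is meant among the compounds shown, and "the series" means these compounds.

Compound 1: `CCc1nn2c(C)cc(C)nc2c1Cc1ccc(-c2nnc(N3CCNCC3)o2)cc1`, 368 nM
Compound 2: `CCc1nc2c(C)cc(C)nn2c1Cc1ccc(/C=C/CN2CCN(C(C)C)CC2)cc1`, 74 nM
Compound 3: `CCc1nn2c(C)cc(C)nc2c1Cc1ccc(/C=C/CN2CCNC(=O)C2)cc1`, 27 nM

The three measured compounds share one core and differ in the group carried by the phenyl ring. In a functional assay on HeLa cells for antagonist activity at G-prodeshotein coupled receptor 4 (Homo sapiens), read by HTRF and cAMP accumulation, with a stated time of 15 min (on this read-out higher numbers stand for weaker inhibition and lower numbers for stronger inhibition), compound 1, with its oxadiazole linked to a piperazine, gives 368 nM. Compound 2, which carries a propenyl chain ending in an isopropylpiperazine, gives 74 nM in this assay. Compound 3, with the same propenyl chain but a 3-oxopiperazin-1-yl at its end, gives 27 nM in this assay, the lowest of the three numbers; the gaps to compound 2 and to compound 1 both lie beyond the usual scatter.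

Compound 4, `CCc1nn2c(C)cc(C)nc2c1Cc1ccc(/C=C/CN2CCNCC2=O)cc1`, has not yet been measured. It differs from compound 3 only in the arrangement of the ring at the chain end: 2-oxopiperazin-1-yl in place of 3-oxopiperazin-1-yl on a saturated chain carbon bound to a double-bonded chain carbon. The two have the same atoms, joined differently, and the counts of donors and acceptors are unchanged.

Among the measured compounds shown here, with no measured pair of this kind to draw on, the size of the step is uncertain. Compound 4 is expected to stay close to compound 3 in this assay, with a step of a 1.7-fold higher number from compound 3 to compound 4 (0.22 log units; within the scatter) that is expected to fall within the scatter. Compound 4 is estimated at 45 nM, with a range from 15 nM to 150 nM.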

Compound 4, half-maximal inhibitory concentration: 73 nM
Estimate against measurement, compound 4: 1.6-fold (0.21 log units) below; the measured number falls inside the stated range.
By their numbers in this assay, from the lowest: compound 3; then compounds 4 and 2 (each within the scatter of the next); then compound 1.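

In this assay, among the compounds shown here, this pair gives the first reading of the carbonyl's place within the oxopiperazine: with the shared core and the propenyl chain held fixed, and with the same atoms and the same counts of donors and acceptors, the change alone produces a 2.7-fold higher number from compound 3 to compound 4 (0.43 log units; beyond the scatter) on this read-out. The earlier compounds shown here differ in more than one place, so they could not show that the arrangement of the ring at the chain end matters on its own, and this pair shows that it does, with the lower number going to 3-oxopiperazin-1-yl. Nothing measured here accounts for the step.

The compounds shown rest this finding on a single pair, so they leave open whether 3-oxopiperazin-1-yl would keep the lower number on another linker, such as the oxadiazole of compound 1. They also leave open how a morpholine, or a 2-oxopiperazin-1-yl or 3-oxopiperazin-1-yl carrying a methyl on the ring, would read on a saturated chain carbon bound to a double-bonded chain carbon.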